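A few compounds are considered here, and "the series" means these few. Any claim that something is new, unique, unknown or untested is made for them only; others in the source may bear on it.

Measured compounds in an assay on isolated protein for inhibition of cytochrome P450 26A1 (Homo sapiens), read by scintillation counting; on this read-out lower numbers stand for stronger inhibition and higher numbers for weaker inhibition:
compound 1, `CCOC(=O)C(C)(C)C(c1ccc(Nc2ccc3ccccc3c2)cc1)n1ccnc1`, 0.35 nM
compound 2, `CCCCOC(=O)C(C)(C)C(c1ccc(Nc2ccc3ccccc3c2)cc1)n1ccnc1`, 200 nM
compound 3, `CC(C)OC(=O)C(C)(C)C(c1ccc(Nc2ccc3ccccc3c2)cc1)n1ccnc1`, 290 nM

Compound 3 stands at the highest number of the three in this assay. Its nearest neighbour is compound 2, and the gap between them, a 1.5-fold higher number from compound 2 to compound 3 (0.16 log units; within the scatter), lies within the scatter; against compound 1 the gap is large, an 830-fold higher number from compound 1 to compound 3 (2.92 log units; beyond the scatter).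

Compound 4, `CC(C)(C(N)=O)C(c1ccc(Nc2ccc3ccccc3c2)cc1)n1ccnc1`, follows from compound 3 by a single change at the carbonyl carbon: amino in place of isopropoxy on a carbonyl carbon. Among the measured compounds shown here, two measured steps touch the same end of the molecule. Enlarging the group on the oxygen next to the carbonyl from ethyl to butyl gave a 570-fold higher number from compound 1 to compound 2 (2.76 log units; beyond the scatter), and going from ethyl to isopropyl gave an 830-fold higher number from compound 1 to compound 3 (2.92 log units; beyond the scatter); both are large. Neither step, however, replaces the oxygen-linked group with amino, so none of them tells directly how this assay will respond to compound 4. The measured series shows only that this position is sensitive to the size of what sits there, and amino is the smallest group tried so far. Compound 4 is therefore expected to improve on compound 3, with a 4.8-fold lower number from compound 3 to compound 4 (0.68 log units; beyond the scatter) as the estimated step, while the value remains uncertain. Compound 4 is estimated at 60 nM, with a range from 5 nM to 600 nM.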

Compound 4, half-maximal inhibitory concentration: 50 nM
Compound 4: middle estimate off by 1.2-fold (0.08 log units), on the high side; low and high end bracket the measured number.
By their numbers in this assay, from the lowest: compound 1; then compound 4; then compounds 2 and 3 (each within the scatter of the next).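

In this assay the change to amino gives a 5.8-fold lower number from compound 3 to compound 4 (0.76 log units; beyond the scatter) and, measured against the butyl ester, a 4.0-fold lower number from compound 2 to compound 4 (0.60 log units; beyond the scatter) so a carbamoyl group at this carbonyl carbon stands clearly lower than either of the two larger esters. It does not match the ethyl ester, however, as the step in the other direction shows, with a 140-fold higher number from compound 1 to compound 4 (2.15 log units; beyond the scatter) and this places compound 4 in the wide gap that the three esters had left open. The earlier compounds allowed the reading that a smaller group here gives a lower number, but compound 4 goes against it: amino is smaller than ethoxy, yet compound 1 keeps the lowest number, and nothing given here explains this.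

On these data alone, what stays open is whether the sharp sensitivity belongs to the ester oxygen or to the size of the group alone, which a methoxy group or a methylamino group on the same carbonyl carbon would help to separate. Also open, as far as these compounds go, is how a free carboxylic acid or a dimethylamino group at this place would stand against compound 1 and compound 4 in this assay.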